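Phenyl in Place of Fluoro: Expected Cytotoxicity of Compound 4

The source may hold more compounds than are shown below. What is called first, only, known or untested is meant among the compounds shown, and "the series" means these compounds.

Compound 1, `O=C(O)c1ccc(C(=O)/C=C/c2ccc3c(c2)B(O)OC3)cc1`, gives in an ADME assay on L929 cells (Mus musculus) for cytotoxicity, read by resazurin assay, with a stated time of 72 h (on this read-out higher numbers stand for weaker inhibition and lower numbers for stronger inhibition), a limit of > 10 ug/mL.
Compound 2, `CCc1ccc(C(=O)/C=C/c2ccc3c(c2)B(O)OC3)cc1`, gives in this assay a limit of > 10 ug/mL.
Compound 3, `O=C(/C=C/c1ccc2c(c1)B(O)OC2)c1ccc(F)cc1`, gives in this assay a limit of > 10 ug/mL.

Compound 3 thus sits at the limit of > 10 ug/mL in this assay, at which 3 of the 3 values shown sit, alongside both other measured compounds. Going by the values given here, the three steps among them, a step that the two limits leave unreadable from compound 1 to compound 2, a step that the two limits leave unreadable from compound 1 to compound 3 and a step that the two limits leave unreadable from compound 2 to compound 3, are all unreadable, so no measured step shows how a change on that aromatic carbon moves the read-out. Compound 4, `O=C(/C=C/c1ccc2c(c1)B(O)OC2)c1ccc(-c2ccccc2)cc1`, differs from compound 3 by phenyl in place of fluoro on an aromatic carbon. With no readable step to lean on, compound 4 is expected to show a step that the limit leaves unreadable from compound 3 to compound 4, which is no step beyond the scatter. Compound 4 is therefore estimated at 15 ug/mL, ranging from 5 ug/mL to 40 ug/mL, most likely reported again as a limit.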

Compound 4, half-maximal inhibitory concentration: > 10 ug/mL
Compound 4 was reported as a limit; the forecaster's own chance of this, stated with the estimate: 65%; the middle value does not contradict the limit.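

Going by these compounds alone, compound 1, compound 2, compound 3 and compound 4 all give only a limit in this assay, so no step to compound 4 can be read. The compounds shown leave open whether any change on that aromatic carbon moves the read-out.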